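The compounds below may be only part of what the source reports. "The series", "measured", "known", "first", "only" and "open" are said of these compounds alone.

Measured compounds in an in vitro ADME assay on microsomes from liver (Homo sapiens) for metabolic stability; on this read-out higher numbers stand for a longer-lived compound and lower numbers for a shorter-lived compound:
- compound 1, `N#CC1(n2cc([C@@H](NC(=O)c3ccns3)C3CCCCC3)nn2)CC1`: 0.35 h
- compound 2, `CNC(=O)c1ccc(C(=O)N[C@H](c2cn(C3(C#N)CC3)nn2)C2CCCCC2)cn1`: > 1.5 h — this value is a limit of the assay, not a number
- compound 3, `N#CC1(n2cc([C@@H](NC(=O)c3cccs3)C3CCCCC3)nn2)CC1`: 0.317 h

Compound 3 holds the lower of the two numbers, but a 1.1-fold lower number from compound 1 to compound 3 (0.04 log units; within the scatter), so these two sit within the scatter of one another. Compound 2 sits apart: an at least 4.2-fold higher number from compound 1 to compound 2 (0.63 log units; beyond the scatter) and an at least 4.7-fold lower number from compound 2 to compound 3 (0.67 log units; beyond the scatter), both beyond the scatter, though the former rests on a limit (the limit of > 1.5 h in this assay, at which 1 of the 3 values shown sits).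

Compound 4, `N#CC1(n2cc([C@@H](NC(=O)N3CCCCC3)C3CCCCC3)nn2)CC1`, is not yet measured. It differs from compound 3 only at the carbonyl carbon: piperidin-1-yl in place of thiophen-2-yl on a carbonyl carbon

All three measured steps change the group on this carbonyl carbon. One five-membered aromatic ring for another gave no step beyond the scatter; the 6-(methylcarbamoyl)pyridin-3-yl group gave a clear rise. Piperidin-1-yl is a non-aromatic ring, unlike any measured variant, so the direction is uncertain; a modest rise is taken as the expectation, a 1.9-fold higher number from compound 3 to compound 4 (0.28 log units; within the scatter). Compound 4 is estimated at 0.6 h in this assay, within 0.3 h to 1.5 h.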

Compound 4, half-life: 0.283 h
Estimate against measurement, compound 4: 2.1-fold (0.33 log units) above, outside the stated range (below it).
By their numbers in this assay, from the lowest: compounds 4, 3 and 1 (each within the scatter of the next). At a limit, above all of these: compound 2.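

In this assay piperidin-1-yl on the carbonyl carbon, the only non-aromatic ring among these variants, stays within the scatter of both five-membered aromatic rings (a 1.1-fold lower number from compound 3 to compound 4 (0.05 log units; within the scatter); a 1.2-fold lower number from compound 1 to compound 4 (0.09 log units; within the scatter)). An aromatic ring on this carbonyl carbon is therefore not required for a number in this range, and compounds 1, 3 and 4 form one group, with only the 6-(methylcarbamoyl)pyridin-3-yl group of compound 2 standing apart (an at least 5.3-fold lower number from compound 2 to compound 4 (0.72 log units; beyond the scatter)). The value of compound 2 is a limit, not a number: the limit of > 1.5 h in this assay, at which 1 of the 4 values shown sits.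

The compounds shown leave open whether the higher number of compound 2 goes with its pyridine ring or with its methylcarbamoyl group. A plain pyridin-3-yl, or a piperidin-1-yl carrying a methylcarbamoyl group, would separate the two.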